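Moving the trifluoromethyl from meta to para position

This account rests on a few compounds, and the source may have more. Where it says the series, first, only, none or still open, it means among the compounds named here.

Measured compounds:
- Compound 1, `O=C(NCc1cc(C(F)(F)F)nn1-c1cccc(C(F)(F)F)c1)Nc1cccc2[nH]ncc12`: 1.3 nM
- Compound 2, `O=C(NCc1cc(C(F)(F)F)nn1-c1ccc(C(F)(F)F)cc1)Nc1cccc2[nH]ncc12`: 3.8 nM
- Compound 3, `Cn1ncc2c(NC(=O)NCc3cc(C(F)(F)F)nn3-c3cccc(C(F)(F)F)c3)cccc21`: 1.4 nM

Of the compounds shown here, three have been measured in an assay on CHO-K1 cells for antagonist activity at transient receptor potential cation channel subfamily V member 1 (Homo sapiens), read by FLIPR and calcium flux, with a stated time of 6 min; a higher number here means a weaker inhibitor, a lower number a stronger inhibitor. Compound 1 gives 1.3 nM in this assay. Compound 2 gives 3.8 nM, and the step of a 2.9-fold higher number from compound 1 to compound 2 (0.47 log units; beyond the scatter) shows that exchanging the phenyl substitution pattern costs potency. Compound 3 gives 1.4 nM, and the step of a 1.1-fold higher number from compound 1 to compound 3 (0.03 log units; within the scatter) shows that the methyl on the aromatic nitrogen of compound 3 leaves the number essentially unchanged. Compound 3 thus stands second highest of the three numbers: within the scatter of compound 1, and beyond the scatter of compound 2.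

Compound 4, `Cn1ncc2c(NC(=O)NCc3cc(C(F)(F)F)nn3-c3ccc(C(F)(F)F)cc3)cccc21`, has not yet been measured. It differs from compound 3 by 4-(trifluoromethyl)phenyl in place of 3-(trifluoromethyl)phenyl on an aromatic nitrogen. Among the compounds with values here, the only measured step that bears on this change is a 2.9-fold higher number from compound 1 to compound 2 (0.47 log units; beyond the scatter), the same exchange of the phenyl group on the unmethylated core, which gave a modest loss beyond the scatter. Because a 1.1-fold higher number from compound 1 to compound 3 (0.03 log units; within the scatter) shows the methyl to be nearly neutral, the same modest loss is expected here, so compound 4 is expected to give 4 nM in this assay, with a range from 2 nM to 8 nM, a step of a 2.9-fold higher number from compound 3 to compound 4 (0.46 log units; beyond the scatter) expected.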

Compound 4, inhibition constant: 3.9 nM
Compound 4: the middle estimate sits 1.0-fold (0.01 log units) above what was measured; low and high end bracket the measured number.
By their numbers in this assay, from the lowest: compounds 1 and 3 (each within the scatter of the next); then compounds 2 and 4 (each within the scatter of the next).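

In this assay, 4-(trifluoromethyl)phenyl in place of 3-(trifluoromethyl)phenyl on the aromatic nitrogen gives a 2.8-fold higher number from compound 3 to compound 4 (0.44 log units; beyond the scatter), so the loss is not confined to the core of compound 1 but recurs on the core that carries the methyl, and the two steps agree: the same change on two cores in this assay, a 2.9-fold higher number (0.47 log units; beyond the scatter) from compound 1 to compound 2 and a 2.8-fold higher number (0.44 log units; beyond the scatter) from compound 3 to compound 4, 1.0-fold (0.02 log units) apart, within the scatter of two such steps. Methyl in place of hydrogen on an aromatic nitrogen, now read with 4-(trifluoromethyl)phenyl present, gives a 1.0-fold higher number from compound 2 to compound 4 (0.01 log units; within the scatter), so the methyl stays without visible effect with either phenyl group: the same change on two cores in this assay, a 1.1-fold higher number (0.03 log units; within the scatter) from compound 1 to compound 3 and a 1.0-fold higher number (0.01 log units; within the scatter) from compound 2 to compound 4, 1.0-fold (0.02 log units) apart, within the scatter of two such steps. Across these four compounds the two changes show no sign of depending on each other, and the number follows the place of the trifluoromethyl on the phenyl ring, with no compound going against this.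

Only hydrogen and methyl are shown on the nitrogen of the shared core, so it stays open whether a longer chain such as ethyl or 2-hydroxyethyl would also leave the number unchanged. Also open, going by these compounds, is why the 4-(trifluoromethyl)phenyl gives the higher number, and whether the step would hold with a chlorine or a nitrile in place of the trifluoromethyl on the phenyl ring.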